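The source may report more compounds than this note shows. Statements on the series, on what has been measured and on what is new or still open speak of the compounds shown alone.

Compound 1 `COc1ccc(N/C=C\C(=O)c2cn(-c3ccccc3)nc2-c2ccc(OC)cc2)cc1` is the reference point of this small set. In a functional assay on HT-29 cells (Homo sapiens) for antiproliferative activity, read by MTT assay, with a stated time of 48 h (on this read-out lower numbers stand for stronger inhibition and higher numbers for weaker inhibition), compound 1 gives 8760 nM. Compound 2 `COc1ccc(-c2nn(-c3ccccc3)cc2C(=O)/C=C\Nc2cc(OC)c(OC)c(OC)c2)cc1` carries one change relative to compound 1, namely (3,4,5-trimethoxyphenyl in place of 4-methoxyphenyl on an amine nitrogen). In this assay compound 2 gives 14600 nM, which amounts to a 1.7-fold higher number from compound 1 to compound 2 (0.22 log units; within the scatter). Compound 3 `COc1ccc(N/C=C\C(=O)c2cn(-c3ccccc3)nc2-c2cc(OC)c(OC)c(OC)c2)cc1` differs from compound 1 in the core itself: 3,4,5-trimethoxyphenyl in place of 4-methoxyphenyl on an aromatic carbon. In this assay compound 3 gives 5780 nM, corresponding to a 1.5-fold lower number from compound 1 to compound 3 (0.18 log units; within the scatter). The gap between compound 3 and compound 2 lies beyond the scatter, while that between compound 3 and compound 1 does not.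

Compound 4 `COc1cc(N/C=C\C(=O)c2cn(-c3ccccc3)nc2-c2cc(OC)c(OC)c(OC)c2)cc(OC)c1OC` has not been measured. Relative to compound 3 it carries 3,4,5-trimethoxyphenyl in place of 4-methoxyphenyl on an amine nitrogen. Within the data shown here, this is the same change that separates compound 1 from compound 2, made at a place described in identical words, so the measured pair gives the only guide available. Among the measured compounds shown here, for compound 4 the expected step is a 1.6-fold higher number from compound 3 to compound 4 (0.22 log units; within the scatter), set beside a 1.7-fold higher number from compound 1 to compound 2 (0.22 log units; within the scatter) because a 1.7-fold higher number from compound 1 to compound 2 (0.22 log units; within the scatter) is the one measured instance of this change. Compound 4 is therefore estimated at 9500 nM, with a plausible range from 4500 nM to 20000 nM.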

Compound 4, half-maximal inhibitory concentration: 8400 nM
Beside the measured number, compound 4's estimate is 1.1-fold (0.05 log units) above it, and the stated range covers the measured number.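

In this assay the 3,4,5-trimethoxyphenyl group in place of 4-methoxyphenyl on an amine nitrogen gives a 1.5-fold higher number from compound 3 to compound 4 (0.16 log units; within the scatter), and this agrees with the same change made on the core of compound 1: the same change on two cores in this assay, a 1.7-fold higher number (0.22 log units; within the scatter) from compound 1 to compound 2 and a 1.5-fold higher number (0.16 log units; within the scatter) from compound 3 to compound 4, 1.1-fold (0.06 log units) apart, within the scatter of two such steps. The same replacement on an aromatic carbon gives a 1.7-fold lower number from compound 2 to compound 4 (0.24 log units; within the scatter), and it also agrees with its earlier instance: the same change on two cores in this assay, a 1.5-fold lower number (0.18 log units; within the scatter) from compound 1 to compound 3 and a 1.7-fold lower number (0.24 log units; within the scatter) from compound 2 to compound 4, 1.1-fold (0.06 log units) apart, within the scatter of two such steps. Both changes therefore read alike on the two cores, but each step lies within the scatter, so this shows neither that either change has a real effect on its own nor that the agreement would hold on any further core.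

The compounds shown leave open how a plain phenyl, a chlorophenyl or a group bearing a carboxylic acid would read in place of these methoxy-substituted rings. They also leave open whether any such replacement would give a step beyond the scatter in this series.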